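The compounds below may be only part of what the source reports. "The series", "measured", "known", "first", "only" and "open" are said of these compounds alone.

Three compounds share one core. In an ADME assay on the whole organism with Oryza sativa as the target, tested at 0.1 uM (on this read-out lower numbers stand for a stronger effect and higher numbers for a weaker effect at the one concentration tested), compound 1 `CC(C)c1ccccc1NC(=O)N[C@H](C)c1ccccc1` gives 103%. Compound 2 `CC(C)c1ccc(NC(=O)N[C@H](C)c2ccccc2)cc1` gives 99% in this assay, and compound 3 `CC(C)c1ccc(NC(=O)N[C@@H](C)c2ccccc2)cc1` gives 98% in this assay, the lowest of the three numbers yet within the scatter of both others. Going by the values given here, the only measured step, a number 1 percentage points lower from compound 2 to compound 3 (within the scatter), rests on the fact that compounds 2 and 3 differ only in the configuration as drawn and stays within the scatter.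

Compound 4 `CCOC(=O)c1ccc(NC(=O)N[C@@H](C)c2ccccc2)cc1` differs from compound 3 by ethoxycarbonyl in place of isopropyl on an aromatic carbon. Among the compounds with values here, no measured step exchanges one group for another, so none bears directly on this change, and all numbers so far sit close together near the top of the scale. The expected step of no change at the digits printed from compound 3 to compound 4 (within the scatter) is therefore small. Compound 4 is estimated to give about 98% in this assay, between 85% and 108%.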

Compound 4, a percentage reported as activity, at one concentration (the size of the read-out at that concentration, not a potency): 99%
Beside the measured number, compound 4's estimate is 1 percentage points below it; low and high end bracket the measured number.
By their numbers in this assay, from the lowest: compounds 3, 2, 4 and 1 (each within the scatter of the next).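

In this assay, putting ethoxycarbonyl in place of isopropyl on an aromatic carbon, para to a large group, gives a number 1 percentage points higher from compound 3 to compound 4 (within the scatter). Going by these compounds alone, this is the first measured exchange of one group for another at this position, and it shows that a group with hydrogen-bond acceptors can stand here without moving the read-out beyond the scatter. Within the data shown here, nothing measured so far explains this result. Still open, from the compounds shown here alone, is whether an amine or a carboxylic acid at this position would give a number beyond the scatter of compound 3.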